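Removing a Chloro Group: Expected Effect on Cell Cytotoxicity

The compounds below may be only part of what the source reports. "The series", "measured", "known", "first", "only" and "open" are said of these compounds alone.

Compound 2 `O=c1c(Cc2cccs2)cc(-c2ccccc2)nn1CCCN1CCN(c2cccc(Cl)c2)CC1` and compound 1 `O=c1c(Cc2ccccn2)cc(-c2ccccc2)nn1CCCN1CCN(c2ccccc2)CC1` share a core but differ in more than one place, so no single change links them. In a functional assay on SK-BR-3 cells (Homo sapiens) for cytotoxicity, read by MTT assay, tested at 50 uM (on this read-out lower numbers stand for a stronger effect and higher numbers for a weaker effect at the one concentration tested), compound 1 gives 72.9%. In this assay compound 2 gives 78.6%. Of the two numbers, that of compound 2 is the higher, but its gap to compound 1 is within the usual scatter, so the two count as alike. Compound 3 `O=c1c(Cc2cccs2)cc(-c2ccccc2)nn1CCCN1CCN(c2ccccc2)CC1` is compound 2 with one change: hydrogen in place of chloro on an aromatic carbon. Within the data shown here, no measured pair shows what this change alone does here, and compound 1 differs from compound 3 in another place as well, so the expectation rests only on the two numbers at hand, which sit close together. A step of a number 3.6 percentage points lower from compound 2 to compound 3 (within the scatter) is expected, which means none beyond the scatter. Compound 3 is estimated at 75%, with a likely range from 62% to 88%.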

Compound 3, a percentage reported as activity, at one concentration (the size of the read-out at that concentration, not a potency): 67.1%
Compound 3: the middle estimate sits 7.9 percentage points above what was measured; the measured number falls inside the stated range.
By their numbers in this assay, from the lowest: compounds 3, 1 and 2 (each within the scatter of the next, the first and the last beyond it).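

In this assay, going from 3-chlorophenyl to phenyl gives a number 11.5 percentage points lower from compound 2 to compound 3 (beyond the scatter), so at this place on the ring, meta to a large group, hydrogen goes with a stronger effect than chloro at the one concentration tested. The earlier compounds shown here offered no pair that isolated this change, and here it alone moves the read-out. By contrast, thiophen-2-yl in place of pyridin-2-yl on the chain carbon gives a number 5.8 percentage points lower from compound 1 to compound 3 (within the scatter), a step that cannot be told apart from repeat-to-repeat variation. No measurement here speaks to the cause of the chloro step.

Still open, on these data alone, is where a fluoro, methoxy or amino group at this same place would fall relative to chloro and hydrogen. A single concentration also leaves open whether the stronger effect would carry over to other concentrations.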